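Methoxy for dimethylamino on a benzofuran-bearing nucleoside

This account rests on a few compounds, and the source may have more. Where it says the series, first, only, none or still open, it means among the compounds named here.

Four nucleosides share one core and differ at two sites. Compound 1 `COc1ncnc2c1c(-c1cccs1)cn2[C@@H]1O[C@H](CO)[C@@H](O)[C@H]1O` carries a methoxy group and a thiophen-2-yl group; in a functional assay on CCRF-CEM cells (Homo sapiens), read by MTT assay, with a stated time of 72 h (a higher number here means a weaker inhibitor, a lower number a stronger inhibitor), compound 1 gives 90 nM. Compound 2 `CN(C)c1ncnc2c1c(-c1cccs1)cn2[C@@H]1O[C@H](CO)[C@@H](O)[C@H]1O` carries dimethylamino in place of that methoxy. In this assay compound 2 reaches only the limit > 20000 nM. Compound 3 `CN(C)c1ncnc2c1c(-c1cc3ccccc3o1)cn2[C@@H]1O[C@H](CO)[C@@H](O)[C@H]1O` keeps the dimethylamino group and carries 1-benzofuran-2-yl in place of thiophen-2-yl. In this assay compound 3 likewise reaches only the limit > 20000 nM.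

The measured change at the six-membered ring is methoxy in place of dimethylamino on an aromatic carbon, and it made the step of an at least 220-fold lower number from compound 2 to compound 1 (2.34 log units; beyond the scatter). The change between the two cores is 1-benzofuran-2-yl in place of thiophen-2-yl on an aromatic carbon, with the step that the two limits leave unreadable from compound 2 to compound 3; that step cannot be read because of the limit of > 20000 nM in this assay, at which 2 of the 3 values shown sit.

Compound 4 `COc1ncnc2c1c(-c1cc3ccccc3o1)cn2[C@@H]1O[C@H](CO)[C@@H](O)[C@H]1O` is not yet measured. It differs from compound 3 by methoxy in place of dimethylamino on an aromatic carbon, and the place is described in the same words as for the change from compound 2 to compound 1, so it is the same change. The expected step is an at least 66-fold lower number from compound 3 to compound 4 (1.82 log units; beyond the scatter), resting on the step of an at least 220-fold lower number from compound 2 to compound 1 (2.34 log units; beyond the scatter); the two methoxy compounds 1 and 4 then differ only by the core change, whose size is unreadable here. Compound 4 is therefore estimated at 300 nM, between 50 nM and 4000 nM.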

Compound 4, half-maximal inhibitory concentration: 5370 nM
Beside the measured number, compound 4's estimate is 18-fold (1.25 log units) below it; measured number above the stated range.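

On the core of compound 3, methoxy in place of dimethylamino on an aromatic carbon again lowers the number in this assay, with an at least 3.7-fold lower number from compound 3 to compound 4 (0.57 log units; beyond the scatter), so the direction of the change holds on both cores in these two pairs. This does not show that the size of the step carries from one core to the other: the same change on two cores in this assay, an at least 220-fold lower number (2.34 log units; beyond the scatter) from compound 2 to compound 1 and an at least 3.7-fold lower number (0.57 log units; beyond the scatter) from compound 3 to compound 4; the limit leaves it open whether they differ. With methoxy held constant, the core change gives a 60-fold higher number from compound 1 to compound 4 (1.78 log units; beyond the scatter), so a favourable methoxy step on one core does not ensure the same number on the other, and the corresponding step between the two dimethylamino compounds cannot be read: the limit of > 20000 nM in this assay, at which 2 of the 4 values shown sit.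

As far as these compounds go, how a methylamino or ethoxy group in the same place would read on either core remains open, since only methoxy and dimethylamino are compared here. Also open, from the compounds shown here alone, is whether the large core step seen with methoxy would recur with such groups, or whether it is specific to the methoxy pair of compound 1 and compound 4.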